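This account rests on a few compounds, and the source may have more. Where it says the series, first, only, none or still open, it means among the compounds named here.

Measured compounds:
Compound 1 `O=C(c1ccccc1C(F)(F)F)N(/N=N/c1ccc([N+](=O)[O-])cc1C(F)(F)F)c1ccc([N+](=O)[O-])cc1C(F)(F)F` — 5350 nM
Compound 2 `O=C(c1cccc(C(F)(F)F)c1)N(/N=N/c1ccc([N+](=O)[O-])cc1C(F)(F)F)c1ccc([N+](=O)[O-])cc1C(F)(F)F` — 750 nM

In a functional assay on HeLa cells (Homo sapiens) for cytotoxicity, read by MTT assay, with a stated time of 72 h (on this read-out lower numbers stand for stronger inhibition and higher numbers for weaker inhibition), compound 1 gives 5350 nM, while compound 2 gives 750 nM. Compound 2 thus stands lowest of the two numbers. Going by the values given here, the one known step, a 7.1-fold lower number from compound 1 to compound 2 (0.85 log units; beyond the scatter), came from a change of the same kind: another placing of trifluoromethyl on the phenyl at the carbonyl carbon. Compound 3 `O=C(c1ccc(C(F)(F)F)cc1)N(/N=N/c1ccc([N+](=O)[O-])cc1C(F)(F)F)c1ccc([N+](=O)[O-])cc1C(F)(F)F` takes this further: 4-(trifluoromethyl)phenyl in place of 3-(trifluoromethyl)phenyl on a carbonyl carbon. That step bears on it, yet nothing shows whether this further move helps or hurts, so the expected step of a 1.1-fold lower number from compound 2 to compound 3 (0.03 log units; within the scatter) is small, within the scatter. Compound 3 is estimated at 700 nM, ranging from 250 nM to 2000 nM.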

Compound 3, half-maximal inhibitory concentration: 690 nM
Estimate against measurement, compound 3: 1.0-fold (0.01 log units) above; low and high end bracket the measured number.
By their numbers in this assay, from the lowest: compounds 3 and 2 (each within the scatter of the next); then compound 1.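

In this assay the shift of trifluoromethyl gives a 1.1-fold lower number from compound 2 to compound 3 (0.04 log units; within the scatter) and so separates 4-(trifluoromethyl)phenyl from 3-(trifluoromethyl)phenyl by no more than ordinary assay variation. Set against 2-(trifluoromethyl)phenyl, the 4-(trifluoromethyl)phenyl group gives a 7.8-fold lower number from compound 1 to compound 3 (0.89 log units; beyond the scatter) and so, among these three placings, only 2-(trifluoromethyl)phenyl stands apart. No measurement available here explains this difference. Still open, on these data alone, is how a phenyl without trifluoromethyl would compare, or one carrying a methoxy group, an amine or a carboxylic acid instead.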